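Swapping ethyl for bromo on the aromatic ring

The source may hold more compounds than are shown below. What is called first, only, known or untested is meant among the compounds shown, and "the series" means these compounds.

Measured in a functional assay on 786-0 cells (Homo sapiens) for inhibition, read by sulforhodamine B assay, with a stated time of 48 h; on this read-out lower numbers stand for stronger inhibition of growth and higher numbers for weaker inhibition of growth:
Compound 1 `S=C(N/N=C/c1cccs1)Nc1ccc(Cl)cc1`: 7400 nM
Compound 2 `COc1ccc(NC(=S)N/N=C/c2cccs2)cc1`: > 100000 nM
Compound 3 `CCc1ccc(NC(=S)N/N=C/c2cccs2)cc1`: 82600 nM
Compound 4 `S=C(N/N=C/c1cccs1)Nc1ccc(Br)cc1`: not yet measured

Compound 3 has the higher of the two true numbers at 82600 nM, while compound 1 stands lower at 7400 nM. Compound 2 reads > 100000 nM, which is a limit and not a number.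

The next change is bromo in place of ethyl on an aromatic carbon. The closest measured change, with ethyl in place of chloro, gave an 11-fold higher number from compound 1 to compound 3 (1.05 log units; beyond the scatter). With methoxy in place of chloro, the result was an at least 13-fold higher number from compound 1 to compound 2 (1.13 log units; beyond the scatter). Both steps were large, and both moved away from chloro, which is a halogen like bromo. Going by the values given here, this is only a single precedent, but a large fall in the number in this assay is expected, towards that of compound 1 at 7400 nM. The expected change is a 10-fold lower number from compound 3 to compound 4 (1.01 log units; beyond the scatter). For compound 4 the estimated value is 8000 nM, with an expected range of 2500 nM to 25000 nM.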

Compound 4, concentration for 50% growth inhibition: 4500 nM
Compound 4: middle estimate off by 1.8-fold (0.25 log units), on the high side; low and high end bracket the measured number.
By their numbers in this assay, from the lowest: compounds 4 and 1 (each within the scatter of the next); then compound 3. At a limit, above all of these: compound 2.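

In this assay, the result shows that the low number of compound 1 was not specific to chloro. A second halogen on this aromatic carbon also gives a large drop: an 18-fold lower number from compound 3 to compound 4 (1.26 log units; beyond the scatter), and an at least 22-fold lower number from compound 2 to compound 4 (1.34 log units; beyond the scatter). The second of these steps starts from compound 2, whose reading is a limit and not a number, so its size is only a minimum: the limit of > 100000 nM in this assay, at which 1 of the 4 values shown sits. Bromo in place of chloro gives a 1.6-fold lower number from compound 1 to compound 4 (0.22 log units; within the scatter), so the two halogens cannot be told apart here, and among these four compounds both stand clearly apart from ethyl and methoxy.

From the compounds shown here alone, whether fluoro or iodo on the same carbon would fit this pattern remains open. So does the effect of an amine, a carboxylic acid or a longer chain there, and why halogens go with the lower numbers.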